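The source may report more compounds than this note shows. Statements on the series, on what has been measured and on what is new or still open speak of the compounds shown alone.

In a functional assay on MCF7 cells (Homo sapiens) for antiproliferative activity, read by MTT assay, with a stated time of 72 h (a higher number here means a weaker inhibitor, a lower number a stronger inhibitor), compound 1 (`CCCCCCCCNC[C@@H]1OC[C@H](N)[C@@H]1O`) gives 96600 nM and compound 2 (`CCCCCCCCCCCCNC[C@@H]1OC[C@H](N)[C@H]1O`) gives 12600 nM as the lower of the two numbers, a gap beyond the scatter. Compound 3 (`CCCCCCCCCCCCNC[C@@H]1OC[C@H](N)[C@@H]1O`) differs from compound 2 in one respect (the two compounds have the same atoms and bonds and differ only in configuration as drawn: 1 of 3 stereo elements differ; a stereocentre at a saturated ring carbon is drawn R in compound 2 and S in compound 3). Going by the values given here, no measured pair shows what such a change does in this assay, so no step beyond the scatter is expected, in either direction. An expected 1.1-fold lower number from compound 2 to compound 3 (0.02 log units; within the scatter) is the working figure. For compound 3 the estimated value is 12000 nM (expected range 5000 nM to 30000 nM).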

Compound 3, half-maximal inhibitory concentration: 1800 nM
Estimate against measurement, compound 3: 6.7-fold (0.82 log units) above; measured number outside the range, below it.
By their numbers in this assay, from the lowest: compound 3; then compound 2; then compound 1.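

Configuration at this saturated ring carbon carries real weight in this assay: drawing it S rather than R gives a 7.0-fold lower number from compound 2 to compound 3 (0.85 log units; beyond the scatter). With that S drawing held, the chain change also counts, as butyl in place of hydrogen on a saturated chain carbon, eight bonds along the chain from an amine nitrogen, gives a 54-fold lower number from compound 1 to compound 3 (1.73 log units; beyond the scatter). The first step involves no change of atoms or bonds: the fact that compounds 2 and 3 differ only in the configuration as drawn

Open, as far as these compounds go, is whether the S preference persists with a longer chain on the same core. Also open, from the compounds shown here alone, is whether it survives an amide in place of the free amine.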